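A few compounds are considered here, and "the series" means these few. Any claim that something is new, unique, unknown or untested is made for them only; others in the source may bear on it.

Three analogues that share one core have been measured in a functional assay on FM3A cells (Mus musculus) for inhibition, read by cell counting, with a stated time of 2 days; a lower number here means a stronger inhibitor, a higher number a weaker inhibitor. Compound 1 `C=C(Br)C(=O)Nc1cccc(-c2cn3nc(Cc4cccc(OC)c4)sc3n2)c1` gives 1100 nM in this assay, compound 2 `C=C(Br)C(=O)Nc1cccc(-c2cn3nc(Cc4ccccc4)sc3n2)c1` gives 3000 nM, and compound 3 `C=C(Br)C(=O)Nc1cccc(-c2cn3nc(-c4ccc(C)cc4)sc3n2)c1` gives 1200 nM. Compound 3 thus stands second highest of the three numbers: its nearest neighbour is compound 1, separated by a 1.1-fold higher number from compound 1 to compound 3 (0.04 log units; within the scatter), a gap within the scatter, and its furthest is compound 2, separated by a 2.5-fold lower number from compound 2 to compound 3 (0.40 log units; beyond the scatter).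

Compound 4 `C=C(Br)C(=O)Nc1cccc(-c2cn3nc(-c4cccs4)sc3n2)c1` differs from compound 3 in one place: thiophen-2-yl in place of 4-methylphenyl on an aromatic carbon. Among the compounds with values here, none of the measured steps exchanges one aromatic ring for another of a different size, so the earlier steps bear on this change only indirectly. The step of a 2.5-fold lower number from compound 2 to compound 3 (0.40 log units; beyond the scatter) and the step of a 2.7-fold higher number from compound 1 to compound 2 (0.44 log units; beyond the scatter) show that alterations of this group shift the number in this assay only modestly, while the step of a 1.1-fold higher number from compound 1 to compound 3 (0.04 log units; within the scatter) shows that a quite different aromatic group can leave it essentially unchanged. The step of a 1.3-fold higher number from compound 3 to compound 4 (0.10 log units; within the scatter) is therefore expected to stay close to the scatter, with no clear direction. Compound 4 is estimated at 1500 nM in this assay, with a range from 600 nM to 4000 nM.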

Compound 4, half-maximal inhibitory concentration: 370 nM
Beside the measured number, compound 4's estimate is 4.1-fold (0.61 log units) above it; the whole stated range lies above it.
By their numbers in this assay, from the lowest: compound 4; then compounds 1 and 3 (each within the scatter of the next); then compound 2.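

In this assay, thiophen-2-yl on this aromatic carbon of the five-membered aromatic ring gives a 3.2-fold lower number from compound 3 to compound 4 (0.51 log units; beyond the scatter), showing that the number at this position can fall well below the level shared by compound 1 and compound 3, which lie within the scatter of each other. The same holds against the two benzyl-bearing compounds, with a 3.0-fold lower number from compound 1 to compound 4 (0.47 log units; beyond the scatter) and an 8.1-fold lower number from compound 2 to compound 4 (0.91 log units; beyond the scatter), so compound 4 is the strongest inhibitor of the four, and the last of these steps is the largest seen at this position. The earlier compounds shown here all carried a six-membered aromatic ring here, and this result shows that a smaller five-membered aromatic ring with one hetero atom is not only accepted but gives a lower number than any of them.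

No measurement is available that explains this gain. The compounds shown cannot separate the contributions of ring size, the sulfur and the lost methyl, leaving open how an unsubstituted phenyl, a furan-2-yl or a thiophen-3-yl group would compare here, and whether an added amine or carboxylic acid on the thiophene would keep the lower number.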